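The source may hold more compounds than are shown below. What is called first, only, known or untested is meant among the compounds shown, and "the series" means these compounds.

Compound 3, `CCN(Cc1nc2cc(C(F)(F)F)ccc2nc1-c1ccccc1)c1ccc(F)c(F)c1`, is examined in an assay on isolated protein for inhibition of Dihydrofolate reductase (Homo sapiens), read by spectrophotometry (a higher number here means a weaker inhibitor, a lower number a stronger inhibitor), where compound 3 gives 5000 nM. Two related compounds frame it: compound 1, `CCN(Cc1nc2cc(C(F)(F)F)ccc2nc1-c1ccccc1)c1ccc(C)cc1`, which in this assay gives 4000 nM, and compound 2, `CCN(Cc1nc2cc(C(F)(F)F)ccc2nc1-c1ccccc1)c1ccc(OC)cc1`, which gives 7000 nM. The three numbers sit close together; a 1.3-fold higher number from compound 1 to compound 3 (0.10 log units; within the scatter) and a 1.4-fold lower number from compound 2 to compound 3 (0.15 log units; within the scatter), so compound 3 is not set apart from either neighbour.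

Compound 4, `CCN(Cc1nc2cc(C(F)(F)F)ccc2nc1-c1ccccc1)c1ccc(OC)c(OC)c1`, carries 3,4-dimethoxyphenyl in place of 3,4-difluorophenyl on an amine nitrogen. Going by the values given here, two measured steps bear on this change. The first is a 1.8-fold higher number from compound 1 to compound 2 (0.24 log units; within the scatter), which shows what a single methoxy on the aromatic ring does against a methyl. The second is a 1.4-fold lower number from compound 2 to compound 3 (0.15 log units; within the scatter), which is the reverse direction of the present exchange up to the second methoxy. Both steps were small, and neither left the scatter. The step from compound 3 to compound 4 therefore is not expected to be large; if anything, a slightly higher number is expected, since compound 2 with its single methoxy gave 7000 nM. The expected step is a 1.4-fold higher number from compound 3 to compound 4 (0.15 log units; within the scatter). For compound 4 the estimate in this assay is 7000 nM, with a range from 3500 nM to 14000 nM.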

Compound 4, inhibition constant: 4000 nM
The estimate for compound 4 lay 1.8-fold (0.24 log units) above the measured number; low and high end bracket the measured number.
By their numbers in this assay, from the lowest: compounds 1, 4, 3 and 2 (each within the scatter of the next).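

In this assay, 3,4-dimethoxyphenyl on the amine nitrogen gives a 1.3-fold lower number from compound 3 to compound 4 (0.10 log units; within the scatter), the added methoxy on the aromatic carbon of compound 2 gives a 1.8-fold lower number from compound 2 to compound 4 (0.24 log units; within the scatter), and the exchange for the 4-methylphenyl of compound 1 gives no change at the digits printed from compound 1 to compound 4 (within the scatter), so the new group is not set apart from any of the three earlier ones. The entering group has 10 heavy atoms and 2 hydrogen-bond acceptors, against 8 heavy atoms and 0 hydrogen-bond acceptors for 3,4-difluorophenyl, and this difference in counts comes with no step beyond the scatter among these four compounds. No measurement is available here that bears on why the numbers stay so close.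

Whether any group on this amine nitrogen can carry the number beyond the scatter remains open, as all four aromatic rings shown bear only methyl, methoxy or fluorine, and a ring carrying a carboxylic acid or an amine would test this more sharply. On these data alone, the shared core is also the same throughout, so it remains open whether this insensitivity would hold on any other core.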